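Working notes: from compound 3 to compound 4

This account rests on a few compounds, and the source may have more. Where it says the series, first, only, none or still open, it means among the compounds named here.

All readings in a functional assay on LNCaP cells (Homo sapiens) for cytotoxicity, read by MTT assay (a higher number here means a weaker inhibitor, a lower number a stronger inhibitor), so far are limits and not exact numbers. Compound 1 `COc1ccc2cc([C@H](C)c3nnc(SCc4ccc(Cl)cc4)n3-c3ccc(F)cc3)ccc2c1` gives > 400000 nM as a limit. Compound 2 `COc1ccc2cc([C@H](C)c3nnc(SCc4c(C)cc(C)cc4C)n3-c3cccc(Cl)c3)ccc2c1` gives <= 400000 nM as a limit. Compound 3 `COc1ccc(CSc2nnc([C@@H](C)c3ccc4cc(OC)ccc4c3)n2-c2ccc(Cl)cc2)cc1` stands at <= 400000 nM as a limit too, with no exact number behind it. Compound 4 `COc1cccc(CSc2nnc([C@@H](C)c3ccc4cc(OC)ccc4c3)n2-c2ccc(Cl)cc2)c1` has 3-methoxyphenyl in place of 4-methoxyphenyl on a saturated chain carbon bound to a sulfur in the structure. For the measured compounds named here, no measured pair shows a change of this kind, so a step no larger than the scatter in this assay is expected, with no favoured direction. The estimated move a step that the limit leaves unreadable from compound 3 to compound 4 is therefore small. For compound 4 the expected value is 200000 nM with an estimated range of 50000 nM to 400000 nM and a report as a limit remains quite possible.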

Compound 4, half-maximal inhibitory concentration: 162000 nM
Estimate against measurement, compound 4: 1.2-fold (0.09 log units) above; the range from low to high includes it.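

For the compounds shown here, compound 3 stands only at a limit, <= 400000 nM, so no step to compound 4 can be read. The compounds shown leave open whether 3-methoxyphenyl in place of 4-methoxyphenyl changes the reading at all, and in which direction.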